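The compounds below may be only part of what the source reports. "The series", "measured", "known", "first", "only" and "open" are said of these compounds alone.

Measured so far in an assay on RBL-1 cells for inhibition of Polyunsaturated fatty acid 5-lipoxygenase (Rattus norvegicus); on this read-out lower numbers stand for stronger inhibition and higher numbers for weaker inhibition:
- compound 1 `CC1CN(c2cccc(F)n2)NC(=O)N1`, 6600 nM
- compound 2 `CC1CN(c2cccc(Cl)n2)NC(=O)N1`, 3500 nM
- compound 3 `COc1cccc(N2CCNC(=O)N2)n1`, 9500 nM

Compound 3 gives a number within the scatter of the number for compound 1, whereas its gap to compound 2 lies beyond the scatter, compound 3 standing at weaker inhibition. Compound 4 `COc1cccc(N2CC(C)NC(=O)N2)n1` differs from compound 3 by methyl in place of hydrogen on a saturated ring carbon. Within the data shown here, the only measured single-point step, a 1.9-fold lower number from compound 1 to compound 2 (0.28 log units; within the scatter), concerns a halogen on the aromatic ring and does not bear on this methyl. Compounds 1 and 2 already carry the methyl, but each also differs from compound 3 elsewhere, so their values give no isolated reading of it. Compound 4 is therefore expected to stay within the scatter of compound 3, with a 1.2-fold lower number from compound 3 to compound 4 (0.07 log units; within the scatter) as the estimated step. The estimate for compound 4 in this assay is 8000 nM, ranging from 4000 nM to 16000 nM.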

Compound 4, half-maximal inhibitory concentration: 5500 nM
Compound 4: the middle estimate sits 1.5-fold (0.16 log units) above what was measured, within the range that was stated.
By their numbers in this assay, from the lowest: compounds 2, 4, 1 and 3 (each within the scatter of the next, the first and the last beyond it).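

In this assay, among these compounds, methyl in place of hydrogen on a saturated ring carbon gives the first isolated reading of this change, a 1.7-fold lower number from compound 3 to compound 4 (0.24 log units; within the scatter), which does not separate the two compounds. With the methyl present, methoxy in place of a halogen on an aromatic carbon gives a 1.6-fold higher number from compound 2 to compound 4 (0.20 log units; within the scatter) and a 1.2-fold lower number from compound 1 to compound 4 (0.08 log units; within the scatter), so neither swap separates compound 4 from its halogen counterpart. No evidence is available to explain these readings. On these data alone, whether an ethyl group at this ring carbon, or an amine on the aromatic carbon, would move the number beyond the scatter remains open.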